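The source may report more compounds than this note shows. Statements on the series, on what has been measured and on what is new or still open speak of the compounds shown alone.

Within the data shown here, in a functional assay (trachea) with Cavia porcellus as the target (on this read-out lower numbers stand for stronger inhibition and higher numbers for weaker inhibition), compound 1 `CC(C)=CCn1nc(-c2cccnc2)c2ccccc2c1=O` gives 1380 nM and compound 2 `O=c1c2ccccc2c(-c2cccnc2)nn1Cc1ccccc1` gives 2450 nM, so compound 2 stands within the scatter of the only other measured compound. Among the measured compounds shown here, the one measured step bearing on this position, a 1.8-fold higher number from compound 1 to compound 2 (0.25 log units; within the scatter), also exchanges a group on the saturated chain carbon bound to an aromatic nitrogen. Compound 3 `CC(=O)Cn1nc(-c2cccnc2)c2ccccc2c1=O` carries acetyl in place of phenyl at that place: acetyl in place of phenyl on a saturated chain carbon bound to an aromatic nitrogen. For the measured compounds named here, with only that step to go on, the expected change in this assay is a 1.2-fold higher number from compound 2 to compound 3 (0.09 log units; within the scatter), with no shift beyond the scatter expected in either direction. For compound 3 the estimate is 3000 nM, with an expected range of 1000 nM to 10000 nM.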

Compound 3, half-maximal inhibitory concentration: 40700 nM
Compound 3: the middle estimate sits 14-fold (1.13 log units) below what was measured; measured number outside the range, above it.
By their numbers in this assay, from the lowest: compounds 1 and 2 (each within the scatter of the next); then compound 3.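

Acetyl in place of phenyl on the saturated chain carbon bound to an aromatic nitrogen brings a 17-fold higher number from compound 2 to compound 3 (1.22 log units; beyond the scatter) in this assay and acetyl in place of 2-methylprop-1-en-1-yl brings a 29-fold higher number from compound 1 to compound 3 (1.47 log units; beyond the scatter) so this place is not indifferent to its group, as the first two compounds alone might have suggested. Phenyl and 2-methylprop-1-en-1-yl read alike there, and acetyl alone stands apart. No measured evidence explains the change.

Acetyl differs from both groups in heavy atoms and in carrying a hydrogen-bond acceptor, and the compounds shown do not separate these two differences. On these data alone, how an amine, a carboxylic acid or a longer chain would read at this place stays open.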